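This account rests on a few compounds, and the source may have more. Where it says the series, first, only, none or still open, it means among the compounds named here.

Values in a functional assay, with a stated time of 15 min; on this read-out higher numbers stand for an effect only at larger amounts of compound and lower numbers for an effect already at smaller amounts:
compound 1 `CCCCCCCCCC(=O)Nc1ccc(O)c2ccccc12`: 18000 nM
compound 2 `CCC(=O)Nc1ccc(O)c2ccccc12`: 16000 nM
compound 3 `CC(=O)Oc1ccc(N)c2ccccc12`: > 1000000 nM (a limit, not a number)

Going by the values given here, only two true numbers exist in this assay, and they stand level: a 1.1-fold lower number from compound 1 to compound 2 (0.05 log units; within the scatter). Compound 2 therefore has one close neighbour and no number clearly apart from it.

The next change starts from compound 2 and leads to compound 4 `NC(=O)c1ccc(O)c2ccccc12`: carbamoyl in place of propanoylamino on an aromatic carbon. In words, this is carbamoyl in place of propanoylamino on an aromatic carbon, para to a hydroxy group.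

Among the compounds with values here, the sole measured step, a 1.1-fold lower number from compound 1 to compound 2 (0.05 log units; within the scatter), alters only the chain and leaves the link to the shared core intact, so it is a weak guide here. Within the data shown here, compound 3 sits at the limit of > 1000000 nM in this assay, at which 1 of the 3 values shown sits, which shows only that a member of the series can give no number. A higher number beyond the scatter is expected, with a wide margin. The expected step is a 3.8-fold higher number from compound 2 to compound 4 (0.57 log units; beyond the scatter). Compound 4 is estimated at 60000 nM, with an expected range from 14000 nM to 400000 nM.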

Compound 4, half-maximal effective concentration: 430000 nM
Compound 4: the middle estimate sits 7.2-fold (0.86 log units) below what was measured; the whole stated range lies below it.
By their numbers in this assay, from the lowest: compounds 2 and 1 (each within the scatter of the next); then compound 4. At a limit, above all of these: compound 3.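

In this assay, carbamoyl in place of propanoylamino on an aromatic carbon, para to a hydroxy group, gives a 27-fold higher number from compound 2 to compound 4 (1.43 log units; beyond the scatter). The earlier pair changed only the chain and stayed level, a 1.1-fold lower number from compound 1 to compound 2 (0.05 log units; within the scatter), so this position responds to the change of group in a way that the chain step did not show. Compound 4 still gives a true number, while compound 3 alone stands at a limit, which is not a number: the limit of > 1000000 nM in this assay, at which 1 of the 4 values shown sits.

Still open, going by these compounds, is whether the step follows from the way the carbonyl and nitrogen are attached to the shared core or from the smaller group alone. A carboxylic acid or an amine on this aromatic carbon would show how far the pattern extends beyond carbamoyl and propanoylamino.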